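A few compounds are considered here, and "the series" means these few. Any claim that something is new, unique, unknown or untested is made for them only; others in the source may bear on it.

Compound 1 `O=C(Nc1ccc(Cl)cc1)c1cc([N+](=O)[O-])ccc1Cl`, compound 2 `CC(Cl)C(=O)Nc1cccc(-c2nc3ccccc3s2)c1` and compound 3 `CC(C)(CCl)C(=O)Nc1cccc(-c2nc3ccccc3s2)c1` have been measured in an ADME assay for permeability, using PAMPA; on this read-out lower numbers stand for lower permeability and higher numbers for higher permeability. In this assay compound 1 gives 536 10^-6 cm/s, compound 2 gives 769 10^-6 cm/s and compound 3 gives 891 10^-6 cm/s. Going by the values given here, the only change made in one place among them is a 1.2-fold higher number from compound 2 to compound 3 (0.06 log units; within the scatter). Compound 3 therefore sits among numbers that are all within the scatter of one another: its number lies within the scatter of compound 2 and also within the scatter of compound 1.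

Compound 4 `O=C(Nc1cccc(-c2nc3ccccc3s2)c1)c1ccncc1Cl` differs from compound 3 by 3-chloropyridin-4-yl in place of 1-(chloromethyl)-1-methylethyl on a carbonyl carbon. Among the compounds with values here, no measured step exchanges an alkyl group on this carbonyl carbon for an aromatic ring with a hetero atom; the one step on that carbon, from compound 2 to compound 3, stayed within the scatter. With only this to rest on, compound 4 is expected to give a number close to that of compound 3, the step of a 1.5-fold lower number from compound 3 to compound 4 (0.17 log units; within the scatter) being estimated as no larger than the scatter. Compound 4 is thus estimated at 600 10^-6 cm/s, with a range from 330 10^-6 cm/s to 1000 10^-6 cm/s.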

Compound 4, apparent permeability: 563 10^-6 cm/s
For compound 4 the middle estimate is 1.1-fold (0.03 log units) above the measured one; low and high end bracket the measured number.
By their numbers in this assay, from the lowest: compounds 1, 4, 2 and 3 (each within the scatter of the next).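

In this assay, putting 3-chloropyridin-4-yl on the carbonyl carbon in place of 1-(chloromethyl)-1-methylethyl gives a 1.6-fold lower number from compound 3 to compound 4 (0.20 log units; within the scatter) and putting it in place of 1-chloroethyl gives a 1.4-fold lower number from compound 2 to compound 4 (0.14 log units; within the scatter) in the same read-out. This place, on a carbonyl carbon whose other neighbour is an amide-type nitrogen, has thus now held a six-membered aromatic ring with a hetero atom as well as two open chlorinated alkyl groups, and no step among these three compounds lies beyond the scatter. Nothing available accounts for this result.

The compounds shown leave open whether an amine, a carboxylic acid or a longer chain on this carbonyl carbon would take the number beyond the scatter. They also do not separate the part of the ring nitrogen from that of the chlorine in 3-chloropyridin-4-yl.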